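Replacing the hydroxyketone side chain with a nitro group

This account rests on a few compounds, and the source may have more. Where it says the series, first, only, none or still open, it means among the compounds named here.

Measured compounds:
Compound 1 `COc1ccc(C2=Cc3ccc(F)cc3C(CC(=O)CO)N2c2ccc(Cl)cc2)cc1`: 8500 nM
Compound 2 `COc1ccc(C2=Cc3ccc(F)cc3C(CC(=O)C(C)O)N2c2ccc(Cl)cc2)cc1`: 9900 nM

Two compounds sharing a core have been examined in an ADME assay on TZM cells (Homo sapiens) for cytotoxicity, read by CellTiter-Glo, with a stated time of 48 h; a lower number here means that less compound is tolerated, a higher number that more compound is tolerated. Compound 1 gives 8500 nM, and compound 2 gives 9900 nM. Going by the values given here, on these two numbers compound 2 cannot be separated from compound 1, since the only step between them, a 1.2-fold higher number from compound 1 to compound 2 (0.07 log units; within the scatter), lies within the scatter of the method.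

Compound 3 `COc1ccc(C2=Cc3ccc(F)cc3C(C[N+](=O)[O-])N2c2ccc(Cl)cc2)cc1` differs from compound 2 by a single change: nitro in place of (1-hydroxyethyl)carbonyl on a saturated chain carbon bound to a saturated ring carbon. Among the compounds with values here, the one measured step concerns another part of the same chain, the methyl that enters from compound 1 to compound 2, and it was small; it says nothing direct about the exchange of the hydroxyketone for a nitro group. In this assay, within the data shown here, no measured step bears on the present change, so the step is expected to stay within the scatter, a 1.1-fold lower number from compound 2 to compound 3 (0.04 log units; within the scatter). Compound 3 is therefore estimated at 9000 nM, with a range from 4000 nM to 20000 nM.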

Compound 3, half-maximal cytotoxic concentration: 32200 nM
The estimate for compound 3 lay 3.6-fold (0.55 log units) below the measured number; the measured number lies above the stated range.
By their numbers in this assay, from the lowest: compounds 1 and 2 (each within the scatter of the next); then compound 3.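

In this assay, the group on the saturated chain carbon bound to a saturated ring carbon turns out to matter: nitro in place of (1-hydroxyethyl)carbonyl gives a 3.3-fold higher number from compound 2 to compound 3 (0.51 log units; beyond the scatter), and nitro in place of (hydroxymethyl)carbonyl gives a 3.8-fold higher number from compound 1 to compound 3 (0.58 log units; beyond the scatter). The earlier pair showed only that adding a methyl to the side chain leaves the number within the scatter, whereas exchanging the whole group moves it beyond the scatter, by a modest step, and more compound is tolerated with nitro whichever of the two side chains it replaces. Nothing at hand indicates why the number rises with this exchange.

The compounds shown cannot tell whether the higher number belongs to nitro itself or would follow from the loss of either hydroxyketone side chain with any other group in its place. An amine, a carboxylic acid or a nitrile at this place, or a longer chain ending in nitro, would begin to separate these readings.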